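The source may hold more compounds than are shown below. What is called first, only, known or untested is meant among the compounds shown, and "the series" means these compounds.

Measured so far in a functional assay on the whole organism (Tail, strain ICR) with Mus musculus as the target, in the tail flick test, with a stated time of 60 min, at a dose of 25 umol/kg by the oral route; on this read-out higher numbers stand for a stronger effect at the one dose given and lower numbers for a weaker effect:

compound 1, `O=C(CN(c1nc(Cl)nc2[nH]cnc12)C1CC1)NCC(=O)OCc1ccccc1`: 41.9%
compound 2, `O=C(CN(c1nc(Cl)nc2[nH]cnc12)C1CC1)N[C@@H](CO)C(=O)O`: 39.8%
compound 3, `O=C(O)CNC(=O)CN(c1nc(Cl)nc2[nH]cnc12)C1CC1`: 38.9%

Compound 1 has the highest of the three numbers, but its steps to the others are both within the scatter, so the three compounds are not distinguished here. The step from the benzyl ester to the free acid, a number 3 percentage points lower from compound 1 to compound 3 (within the scatter), changes nothing of note. Compound 4, `CSCC[C@H](NC(=O)CN(c1nc(Cl)nc2[nH]cnc12)C1CC1)C(=O)OCc1ccccc1`, differs from compound 1 only at the saturated chain carbon bound to an amide-type nitrogen and a carbonyl carbon: 2-(methylsulfanyl)ethyl in place of hydrogen on a saturated chain carbon bound to an amide-type nitrogen and a carbonyl carbon.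

Going by the values given here, the one measured step at that same carbon, a number 0.9 percentage points lower from compound 2 to compound 3 (within the scatter), exchanges hydroxymethyl for hydrogen and stays within the scatter. Among the compounds with values here, that is the only guide for the new side chain, and it gives no sign that a substituent at this position moves the read-out. A step of no size beyond the scatter is therefore expected for this assay, a number 0.9 percentage points lower from compound 1 to compound 4 (within the scatter). Compound 4 is thus estimated at 41%, with a range from 28% to 54%.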

Compound 4, a percentage reported as activity, at one dose (the size of the read-out at that dose, not a potency): 30.8%
Compound 4: the middle estimate sits 10.2 percentage points above what was measured; low and high end bracket the measured number.
By their numbers in this assay, from the lowest: compounds 4, 3, 2 and 1 (each within the scatter of the next, the first and the last beyond it).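

In this assay the saturated chain carbon bound to an amide-type nitrogen and a carbonyl carbon proves not to be indifferent to its substituent. With 2-(methylsulfanyl)ethyl in place of hydrogen on the benzyl ester, the series gains its first step beyond the scatter: a number 11.1 percentage points lower from compound 1 to compound 4 (beyond the scatter). The earlier step at this carbon, a number 0.9 percentage points lower from compound 2 to compound 3 (within the scatter), did not show this, as it left hydroxymethyl and hydrogen unseparated on the free acid; no measurement at hand bears on the reason for the lower number with the new side chain.

From the compounds shown here alone, whether the lower number follows from the sulfur atom or from the chain alone stays open, and a plain butyl chain at the same carbon would separate the two. Also open, going by these compounds, is how a side chain ending in an amine would read at this carbon.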